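The compounds below may be only part of what the source reports. "The series", "measured", "known", "first", "only" and "open" are said of these compounds alone.

Three compounds share one core, a methyl-bearing bicyclic amine linked through a piperidine to a carbonyl, and differ in the group beyond that carbonyl. Compound 1 `Cc1nc2cnccc2n1CC1CCN(C(=O)CC(C)c2ccc(N)cc2)CC1` carries a chain with one methyl on the carbon bound to the aminophenyl ring; compound 2 `Cc1nc2cnccc2n1CC1CCN(C(=O)CC(C)(C)c2ccc(N)cc2)CC1` carries two methyls there; compound 3 `Cc1nc2cnccc2n1CC1CCN(C(=O)NC(C)c2ccc(N)cc2)CC1` has a urea-type linker instead. In a functional assay on the whole organism with Oryctolagus cuniculus as the target (a higher number here means a weaker inhibitor, a lower number a stronger inhibitor), compound 1 gives 11 nM, compound 2 gives 19 nM, and compound 3 gives 1600 nM, the highest of the three. Among the measured compounds shown here, the step of a 1.7-fold lower number from compound 2 to compound 1 (0.24 log units; within the scatter) is the only measured step of this kind; the difference between the cores of compound 2 and compound 3 is not broken down here.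

Compound 4 `Cc1nc2cnccc2n1CC1CCN(C(=O)NCc2ccc(N)cc2)CC1` is compound 3 with hydrogen in place of methyl on a saturated chain carbon bound to an amide-type nitrogen and an aromatic carbon. This is the same kind of change as hydrogen in place of methyl on a saturated chain carbon bound to an aromatic carbon and two saturated chain carbons, though the place differs: there the carbon is bound to an aromatic carbon and two saturated chain carbons, here to an amide-type nitrogen and an aromatic carbon. Because a 1.7-fold lower number from compound 2 to compound 1 (0.24 log units; within the scatter) was small, the step is expected to be modest, a 1.3-fold lower number from compound 3 to compound 4 (0.12 log units; within the scatter). Compound 4 is estimated at 1200 nM, between 400 nM and 4000 nM.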

Compound 4, half-maximal inhibitory concentration: 1550 nM
Beside the measured number, compound 4's estimate is 1.3-fold (0.11 log units) below it; low and high end bracket the measured number.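

In this assay, replacing the methyl with hydrogen, which turns 1-(4-aminophenyl)ethyl into 4-aminobenzyl, gives a 1.0-fold lower number from compound 3 to compound 4 (0.01 log units; within the scatter), so on this urea-type core the change has no effect that can be told from assay noise. Set beside the earlier step, the change reads the same on both cores as far as these numbers can tell: the same change on two cores in this assay, a 1.7-fold lower number (0.24 log units; within the scatter) from compound 2 to compound 1 and a 1.0-fold lower number (0.01 log units; within the scatter) from compound 3 to compound 4, 1.7-fold (0.22 log units) apart, within the scatter of two such steps This supports carrying the change from one core to the other within these two pairs, but it rests on only two steps, at carbons with different neighbours, and two small steps cannot show that the change would behave alike on other cores in the series.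

On these data alone, what an ethyl group or a longer chain on that same carbon would do on either core remains open. So does the effect of a carboxylic acid in place of the amine of the 4-aminobenzyl group.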